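The compounds below may be only part of what the source reports. "The series", "measured", "known", "first", "only" and "open" are said of these compounds alone.

Three compounds have numbers in a functional assay on PANC-1 cells (Homo sapiens) for inhibition, read by MTT assay, with a stated time of 24 h, tested at 10 uM; a higher number here means more inhibition at the concentration tested (going by the name of the read-out), a lower number less inhibition:

compound 1, `CC(C)=CCC1Cc2c(OCCCNC(=O)c3ccco3)cc(=O)n(CCCO)c2CC1(C)C`, gives 2.1%
compound 2, `CC(C)=CCC1Cc2c(OCCCNC(=O)c3cccs3)cc(=O)n(CCCO)c2CC1(C)C`, gives 33.6%
compound 3, `CC(C)=CCC1Cc2c(OC(=O)Nc3ccccc3F)cc(=O)n(CCCO)c2CC1(C)C`, gives 52.3%

Compound 3 stands highest of the three in this assay. Its nearest neighbour is compound 2, the step being a number 18.7 percentage points higher from compound 2 to compound 3 (beyond the scatter), and the furthest is compound 1, with a number 50.2 percentage points higher from compound 1 to compound 3 (beyond the scatter). The remaining step, a number 31.5 percentage points higher from compound 1 to compound 2 (beyond the scatter), changes only the heteroaryl on the carbonyl carbon.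

The unmeasured compound 4, `CC(C)=CCC1Cc2c(OC(=O)Nc3ccc(F)c(Cl)c3)cc(=O)n(CCCO)c2CC1(C)C`, differs from compound 3 in one place: 3-chloro-4-fluorophenyl in place of 2-fluorophenyl on an amide-type nitrogen. None of the three measured steps alters the aryl group on the amide-type nitrogen; the two steps that reach compound 3 replace the whole group on the oxygen on the aromatic ring, and the third swaps furan-2-yl for thiophen-2-yl in the amide of compounds 1 and 2. Among the compounds with values here, the measured data therefore contain no step that bears directly on the change from compound 3 to compound 4. With nothing to indicate a direction, compound 4 is expected to sit close to compound 3, and the expected step is a number 0.3 percentage points lower from compound 3 to compound 4 (within the scatter), not beyond the scatter.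

Compound 4 is thus estimated at 52% in this assay, within a range of 30% to 72%.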

Compound 4, a percentage reported as inhibition, at one concentration (the size of the read-out at that concentration, not a potency): 79.8%
Estimate against measurement, compound 4: 27.8 percentage points below; measured number outside the range, above it.
By their numbers in this assay, from the lowest: compound 1; then compound 2; then compound 3; then compound 4.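

In this assay, the aryl group on the amide-type nitrogen proves to be a position where a single change moves the number: 3-chloro-4-fluorophenyl in place of 2-fluorophenyl gives a number 27.5 percentage points higher from compound 3 to compound 4 (beyond the scatter), the only step shown that alters this aryl group while the rest of the molecule stays fixed. The choice of aryl group also affects how far the replacement of the whole group on the oxygen on the aromatic ring reaches, with (3-chloro-4-fluorophenyl)carbamoyl giving a number 46.2 percentage points higher from compound 2 to compound 4 (beyond the scatter) against the thiophene amide and a number 77.7 percentage points higher from compound 1 to compound 4 (beyond the scatter) against the furan amide, where (2-fluorophenyl)carbamoyl gave a number 18.7 percentage points higher from compound 2 to compound 3 (beyond the scatter) and a number 50.2 percentage points higher from compound 1 to compound 3 (beyond the scatter). Nothing shown here offers an explanation for the step at the amide-type nitrogen.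

The entering group differs from the leaving one in both its chlorine and the place of its fluorine, so this single pair cannot tell which of the two matters, and 3-chlorophenyl, 4-fluorophenyl or plain phenyl on the same nitrogen would separate them. All of these numbers also come from one concentration in one cell line, which leaves open whether the order of the compounds would hold as a potency.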